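A few compounds are considered here, and "the series" means these few. Any claim that something is new, unique, unknown or untested is made for them only; others in the source may bear on it.

Measured in a functional assay on MCF7 cells (Homo sapiens) for cytotoxicity, read by MTT assay (on this read-out lower numbers stand for stronger inhibition and higher numbers for weaker inhibition), each value a limit of the assay and not a number:
- compound 1 `COc1ccc(-c2oc3c(CC=C(C)C)c(OC/C=C/C(=O)O)cc(O)c3c(=O)c2O)cc1`: > 100000 nM
- compound 2 `CCOC(=O)COc1c(-c2ccc(OC)cc2)oc2c(CC=C(C)C)c(O)cc(O)c2c1=O`: > 100000 nM
- compound 3 `COc1ccc(-c2oc3c(CC=C(C)C)c(OC/C=C/C(=O)O)cc(O)c3c(=O)c2OC/C=C/C(=O)O)cc1`: > 100000 nM

Compound 1 gives only a limit, > 100000 nM, so its position in this assay is not a point on a scale. The same holds across the set: the limit of > 100000 nM in this assay, at which 3 of the 3 values shown sit. Going by the values given here, no measured compound therefore gives a numerical reference.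

Compound 4 `COc1ccc(-c2oc3c(CC=C(C)C)c(OCC(=O)O)cc(O)c3c(=O)c2O)cc1` carries carboxy in place of 2-carboxyethenyl on a saturated chain carbon bound to an oxygen on an aromatic ring, which shortens 3-carboxyprop-2-en-1-yl to carboxymethyl: carboxy in place of 2-carboxyethenyl on a saturated chain carbon bound to an oxygen on an aromatic ring.

Among the compounds with values here, only one measured step bears on this, and only loosely, since it adds the 3-carboxyprop-2-en-1-yl chain on a further oxygen rather than altering it: a step that the two limits leave unreadable from compound 1 to compound 3. That step has no readable size, so it sets neither a magnitude nor a direction for the change at hand. With compound 1 at > 100000 nM, the working expectation is no readable gain in this assay, and compound 4 will most likely report a limit as well.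

The expected step is a number no higher from compound 1 to compound 4 (the limit leaves the size open). For compound 4 the estimated value is 100000 nM, with an expected range from 30000 nM to 200000 nM.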

Compound 4, half-maximal inhibitory concentration: > 100000 nM
Compound 4: no number, only a limit (the forecaster's own chance of this, stated with the estimate: 80%); the middle value sits exactly at the limit.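

Compound 1 and compound 4 both give only a limit of the assay in this assay, so no step can be read between them, and the change from 3-carboxyprop-2-en-1-yl to carboxymethyl has no readable size. The compounds shown leave open how any of these changes on the shared core acts in this assay, because none gives a number: the limit of > 100000 nM in this assay, at which 4 of the 4 values shown sit.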